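The source may hold more compounds than are shown below. What is called first, only, known or untested is meant among the compounds shown, and "the series" means these compounds.

Compound 1 `COc1ccc([N+](=O)[O-])cc1CSc1nc2cc(NC(=O)NC(C)(C)C)ccc2n1Cc1cccnc1`: in an assay on isolated protein for inhibition of Gonadotropin-releasing hormone receptor (Homo sapiens) (on this read-out higher numbers stand for weaker inhibition and lower numbers for stronger inhibition), compound 1 gives 33 nM.
Compound 2 `COc1ccc([N+](=O)[O-])cc1CSc1nc2cc(NC(=O)NC(C)(C)C)ccc2n1Cc1ccncc1`: in this assay compound 2 gives 47 nM.
Compound 3 `CCCn1c(SCc2cc([N+](=O)[O-])ccc2OC)nc2cc(NC(=O)NC(C)(C)C)cc(C(=O)NCc3ccncc3)c21`: in this assay compound 3 gives 61 nM.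

Compound 1 and compound 2 share a core and differ only by pyridin-3-yl in place of pyridin-4-yl on a saturated chain carbon bound to an aromatic nitrogen; that change gave a 1.4-fold lower number from compound 2 to compound 1 (0.15 log units; within the scatter). Compound 3 is built on another core, and the difference between the two cores is not broken down here. Compound 4 `CCCn1c(SCc2cc([N+](=O)[O-])ccc2OC)nc2cc(NC(=O)NC(C)(C)C)cc(C(=O)NCc3cccnc3)c21` has not yet been measured. It differs from compound 3 by pyridin-3-yl in place of pyridin-4-yl on a saturated chain carbon bound to an amide-type nitrogen, the same kind of change as before, though here the saturated chain carbon is bound to an amide-type nitrogen rather than to an aromatic nitrogen. Because the earlier step of a 1.4-fold lower number from compound 2 to compound 1 (0.15 log units; within the scatter) stayed within the scatter, a step of about a 1.4-fold lower number from compound 3 to compound 4 (0.13 log units; within the scatter) is expected here as well. Compound 4 is therefore estimated at 45 nM in this assay, with a likely range from 20 nM to 110 nM.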

Compound 4, half-maximal inhibitory concentration: 69 nM
Beside the measured number, compound 4's estimate is 1.5-fold (0.19 log units) below it; measured number inside the range.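

In this assay, on the core shared by the newly compared pair, pyridin-3-yl in place of pyridin-4-yl gave a 1.1-fold higher number from compound 3 to compound 4 (0.05 log units; within the scatter). Set beside the earlier case, the two cores show no readable disagreement: the same change on two cores in this assay, a 1.4-fold lower number (0.15 log units; within the scatter) from compound 2 to compound 1 and a 1.1-fold higher number (0.05 log units; within the scatter) from compound 3 to compound 4, 1.6-fold (0.21 log units) apart, within the scatter of two such steps. This shows that the change stayed small on both cores, but not that its effect is truly identical on them, and two cores cannot establish a rule for the whole series.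

Still open, going by these compounds, is whether a pyridin-2-yl, a phenyl ring or a simple amine on this saturated chain carbon would move the number beyond the scatter on either core.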